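The source may hold more compounds than are shown below. What is called first, only, known or untested is meant among the compounds shown, and "the series" means these compounds.

Values measured in a functional assay on HL-60 cells (Homo sapiens) for antiproliferative activity, read by MTT assay, with a stated time of 48 h; on this read-out higher numbers stand for weaker inhibition and lower numbers for stronger inhibition:
- Compound 1 `CN1CCN(CCn2c(N)c(-c3nc4ccccc4[nH]3)c3nc(C#N)c(C#N)nc32)CC1` gives 4300 nM
- Compound 2 `N#Cc1nc2c(-c3nc4ccccc4[nH]3)c(N)n(CCO)c2nc1C#N` has the limit > 50000 nM
- Compound 3 `CCN(CC)CCCn1c(N)c(-c2nc3ccccc3[nH]2)c2nc(C#N)c(C#N)nc21` has the limit > 730 nM

Compound 3 therefore has no exact number to start from, only (the limit of > 730 nM in this assay, at which 1 of the 3 values shown sits). Compound 4 `CCCCn1c(N)c(-c2nc3ccccc3[nH]2)c2nc(C#N)c(C#N)nc21` differs from it by methyl in place of diethylamino on a saturated chain carbon, three bonds along the chain from an aromatic nitrogen. The closest guide is an at least 11-fold higher number from compound 1 to compound 2 (1.06 log units; beyond the scatter), a large step in which a nitrogen-bearing end group also leaves. The other guide, a step that the limit leaves unreadable from compound 1 to compound 3, gives no size. A higher number, meaning weaker inhibition, is therefore expected, though this rests on one step. The expected change is a step that the limit leaves unreadable from compound 3 to compound 4. For compound 4 the estimate is 8000 nM, with an expected range from 1500 nM to 50000 nM.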

Compound 4, half-maximal inhibitory concentration: > 50000 nM
Compound 4: a limit, no number; the forecaster's own chance of this, stated with the estimate: 30%; middle value at least 6.2-fold (0.79 log units) from the limit.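

In this assay compound 4 gives > 50000 nM, which is a limit and not a number. Putting ethyl in place of 4-methylpiperazin-1-yl gives an at least 11-fold higher number from compound 1 to compound 4 (1.06 log units; beyond the scatter), so a plain butyl chain with no amine at its end goes the same way as the hydroxy chain of compound 2. The steps from compound 2 and from compound 3 to compound 4 cannot be read.

As far as these compounds go, how far the diethylamino end of compound 3 contributes therefore stays open. So does how a morpholine or a primary amine at the chain end would compare with 4-methylpiperazin-1-yl.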